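This account rests on a few compounds, and the source may have more. Where it says the series, first, only, none or still open, it means among the compounds named here.

Measured so far in a functional assay on A549 cells (Homo sapiens) for inhibition, read by MTT assay, with a stated time of 72 h; on this read-out lower numbers stand for stronger inhibition and higher numbers for weaker inhibition:

Compound 1 `CN(C(=O)NC(=O)c1ccc(Cl)cc1Cl)c1nc(C(F)(F)F)c(C(=O)N/N=C/c2ccc(C(F)(F)F)cc2)s1`: in this assay compound 1 gives 9.4 ug/mL.
Compound 2 `CNc1nc(C)c(C(=O)N/N=C/c2cccc(C(F)(F)F)c2)s1`: in this assay compound 2 reaches only a limit, > 100 ug/mL.
Compound 3 `CNc1nc(C(F)(F)F)c(C(=O)N/N=C/c2cccc(C(F)(F)F)c2)s1`: in this assay compound 3 likewise reaches only a limit, > 100 ug/mL.

Among the measured compounds shown here, compound 1 is thus the only member of the set with a number; the other two sit at the limit of > 100 ug/mL in this assay, at which 2 of the 3 values shown sit. The change from compound 3 to compound 2 is methyl in place of trifluoromethyl on an aromatic carbon. The step it made, a step that the two limits leave unreadable from compound 3 to compound 2, cannot be sized because the limit of > 100 ug/mL in this assay, at which 2 of the 3 values shown sit, holds both of its ends.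

Compound 4 `Cc1nc(N(C)C(=O)NC(=O)c2ccc(Cl)cc2Cl)sc1C(=O)N/N=C/c1ccc(C(F)(F)F)cc1` is not yet measured. It differs from compound 1 by methyl in place of trifluoromethyl on an aromatic carbon. For the measured compounds named here, this is the same kind of change as the one from compound 3 to compound 2, not the same: around the place, the ring atom two ring bonds away bears a large group in compound 1 and compound 4, whereas in compound 3 and compound 2 it bears a methylamino group (2 heavy atoms). The difference between the cores of compound 1 and compound 3 is not broken down here.

Going by the values given here, since the one measured instance of this change gives no readable size, the expectation for compound 4 rests on compound 1 alone, on its value 9.4 ug/mL in this assay, with a wide margin. The step from compound 1 to compound 4 is expected to be a 1.6-fold higher number from compound 1 to compound 4 (0.20 log units; within the scatter). For compound 4 the estimated value in this assay is 15 ug/mL, expected to lie between 5 ug/mL and 60 ug/mL.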

Compound 4, half-maximal inhibitory concentration: 30.2 ug/mL
Estimate against measurement, compound 4: 2.0-fold (0.30 log units) below; the measured number falls inside the stated range.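

In this assay, methyl in place of trifluoromethyl on an aromatic carbon gives a 3.2-fold higher number from compound 1 to compound 4 (0.51 log units; beyond the scatter), which is the only readable size for this change in the series and applies to the core of compound 1 alone. The same change from compound 3 to compound 2 cannot be read, because both compounds stand at a limit of the assay and not at a number: the limit of > 100 ug/mL in this assay, at which 2 of the 4 values shown sit. From the compounds shown here alone, the change can therefore be said to carry a measurable penalty on one core, but nothing shows whether a step of that size, a smaller one or a larger one applies on the core of compound 3, so the transfer from one core to the other remains untested.

Still open, going by these compounds, is how the aromatic carbon that bears the trifluoromethyl or methyl group responds to other groups, such as an ethyl group, an amine or a carboxylic acid, since only these two groups appear there. Also open is which part of the large group on the core of compound 1 separates compound 1 and compound 4 from the methylamino compounds, as no pair shown differs at that place alone.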